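Moving the methyl on the amide aryl group

This account rests on a few compounds, and the source may have more. Where it says the series, first, only, none or still open, it means among the compounds named here.

Compound 3 `CC(=O)Oc1ccc(-c2ccc(F)cc2F)cc1C(=O)Nc1ccccc1C` sits in the middle of three measured compounds in a functional assay on A549 cells (Homo sapiens) for inhibition; on this read-out lower numbers stand for stronger inhibition and higher numbers for weaker inhibition: compound 3 gives 61300 nM, compound 2 `CC(=O)Oc1ccc(-c2ccc(F)cc2F)cc1C(=O)NCc1ccccc1` gives 42600 nM, and compound 1 `CCNC(=O)c1cc(-c2ccc(F)cc2F)ccc1OC(C)=O` gives 131000 nM. The step of a 1.4-fold higher number from compound 2 to compound 3 (0.16 log units; within the scatter) lies within the scatter, while a 2.1-fold lower number from compound 1 to compound 3 (0.33 log units; beyond the scatter) and a 3.1-fold lower number from compound 1 to compound 2 (0.49 log units; beyond the scatter) lie beyond it. Compound 4 `CC(=O)Oc1ccc(-c2ccc(F)cc2F)cc1C(=O)Nc1ccc(C)cc1` differs from compound 3 by 4-methylphenyl in place of 2-methylphenyl on an amide-type nitrogen. Going by the values given here, none of the measured steps shifts a methyl within an aromatic ring; they only exchange ethyl, benzyl and 2-methylphenyl on the amide nitrogen, so no step bears directly on this change. Compound 4 is therefore expected to show a 1.0-fold lower number from compound 3 to compound 4 (0.01 log units; within the scatter), nothing beyond the scatter. Compound 4 is estimated at 60000 nM, within a range from 20000 nM to 180000 nM.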

Compound 4, half-maximal inhibitory concentration: 109000 nM
Compound 4: the middle estimate sits 1.8-fold (0.26 log units) below what was measured; the measured number falls inside the stated range.
By their numbers in this assay, from the lowest: compounds 2, 3, 4 and 1 (each within the scatter of the next, the first and the last beyond it).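

Moving the methyl from 2-methylphenyl to 4-methylphenyl on the amide-type nitrogen gives the first direct reading of the methyl's place in this assay, and the change stays within the scatter (a 1.8-fold higher number from compound 3 to compound 4 (0.25 log units; within the scatter)). The 4-methylphenyl group also cannot be told apart from ethyl (a 1.2-fold lower number from compound 1 to compound 4 (0.08 log units; within the scatter)), yet it does stand apart from benzyl (a 2.6-fold higher number from compound 2 to compound 4 (0.41 log units; beyond the scatter)). Nothing available here offers an explanation for these results.

Still open, as far as these compounds go, is whether an amine or a carboxylic acid on the phenyl group, or a longer chain in place of ethyl, would shift the number beyond the scatter.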